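Notes on compound 3: methoxy in place of chloro

A few compounds are considered here, and "the series" means these few. Any claim that something is new, unique, unknown or untested is made for them only; others in the source may bear on it.

- compound 1 `COc1cccc(NC(=O)NCCNS(=O)(=O)c2ccc(-c3ccccc3Oc3ccc([N+](=O)[O-])c([N+](=O)[O-])c3)s2)c1` gives 6700 nM in a functional assay on HL-60 cells (Homo sapiens) for inhibition, read by CCK-8 assay, with a stated time of 48 h; a higher number here means a weaker inhibitor, a lower number a stronger inhibitor
- compound 2 `O=C(NCCNS(=O)(=O)c1ccc(-c2ccccc2Oc2ccc([N+](=O)[O-])c([N+](=O)[O-])c2)s1)Nc1ccc(Cl)cc1` gives 8100 nM in this assay

The two measured compounds lie within the scatter of each other, so compound 2 stands level with compound 1 on the numbers available. Compound 3 `COc1ccc(NC(=O)NCCNS(=O)(=O)c2ccc(-c3ccccc3Oc3ccc([N+](=O)[O-])c([N+](=O)[O-])c3)s2)cc1` follows from compound 2 by one change, (methoxy in place of chloro on an aromatic carbon), with methoxy in place of chloro on an aromatic carbon, para to a large group. Among the compounds with values here, only one measured step bears on it: a 1.2-fold higher number from compound 1 to compound 2 (0.08 log units; within the scatter), which exchanges 3-methoxyphenyl for 4-chlorophenyl and stays within the scatter. Within the data shown here, no measured compound yet carries 4-methoxyphenyl, so this support is partial. No step beyond the scatter is therefore expected in this assay for this change. The estimate amounts to a 1.2-fold lower number from compound 2 to compound 3 (0.06 log units; within the scatter) as the expected step. Compound 3 is expected at 7000 nM in this assay, with an estimated range from 3500 nM to 14000 nM for repeat measurements.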

Compound 3, half-maximal inhibitory concentration: 5400 nM
Compound 3: middle estimate off by 1.3-fold (0.11 log units), on the high side, and the stated range covers the measured number.
By their numbers in this assay, from the lowest: compounds 3, 1 and 2 (each within the scatter of the next).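

Methoxy in place of chloro on the aromatic carbon, para to a large group, now has a direct reading in this assay: it gives a 1.5-fold lower number from compound 2 to compound 3 (0.18 log units; within the scatter) and so leaves the two compounds level. Taking 4-methoxyphenyl in place of 3-methoxyphenyl gives a 1.2-fold lower number from compound 1 to compound 3 (0.09 log units; within the scatter), so the placing of the methoxy on this ring separates nothing on these numbers either. No supporting data are at hand to explain why the three compounds stay level.

From the compounds shown here alone, whether an amine, a carboxylic acid or a longer chain on this ring would give a step beyond the scatter remains open. Going by these compounds, the shared core is the same in all three compounds, so how the series responds to changes elsewhere also remains open.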